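Methyl for fluoro on the aryl urea: compound 4

The source may report more compounds than this note shows. Statements on the series, on what has been measured and on what is new or still open speak of the compounds shown alone.

Measured compounds:
Compound 1, `Cc1ccc(NC(=O)N[C@@H](C)c2ccccc2)cc1`, 100%
Compound 2, `C[C@H](NC(=O)Nc1ccc(F)cc1)c1ccccc1`, 85%
Compound 3, `C[C@H](NC(=O)Nc1ccc(F)cc1F)c1ccccc1`, 99%

In an ADME assay on the whole organism with Oryza sativa as the target, tested at 10 uM (on this read-out lower numbers stand for a stronger effect and higher numbers for a weaker effect at the one concentration tested), compound 3 gives 99%, the second highest of the three numbers; it sits within the scatter of compound 1 and is a number 14 percentage points higher from compound 2 to compound 3 (beyond the scatter) after fluoro replaces hydrogen on an aromatic carbon. The unmeasured compound 4, `Cc1ccc(NC(=O)N[C@@H](C)c2ccccc2)c(F)c1`, differs from compound 3 by methyl in place of fluoro on an aromatic carbon, the position being meta to a fluoro group and para to a large group. Going by the values given here, the one measured step that bears on this exchange is the reverse one, a number 15 percentage points lower from compound 1 to compound 2 (beyond the scatter), where fluoro replaced methyl. Read backwards, methyl in place of fluoro would point to a modestly higher number, but compound 3 already stands at a reading that leaves little room above it, so a step within the scatter is expected, a number 1 percentage points higher from compound 3 to compound 4 (within the scatter). Compound 4 is therefore estimated at 100%, in the range 90% to 108%.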

Compound 4, a percentage reported as activity, at one concentration (the size of the read-out at that concentration, not a potency): 100%
For compound 4 middle estimate and measured number coincide at the digits printed, and the stated range covers the measured number.
By their numbers in this assay, from the lowest: compound 2; then compounds 3, 1 and 4 (each within the scatter of the next).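

In this assay, methyl in place of fluoro at this position, meta to a fluoro group and para to a large group, gives a number 1 percentage points higher from compound 3 to compound 4 (within the scatter), while fluoro in place of hydrogen on an aromatic carbon gives no change at the digits printed from compound 1 to compound 4 (within the scatter). The exchange of methyl and fluoro has now been read on two cores, and the clear step seen on the first does not recur on the second, although the gap between the two stays inside what repeat measurements allow: the same change on two cores in this assay, a number 15 percentage points lower (beyond the scatter) from compound 1 to compound 2 and a number 1 percentage points lower (within the scatter) from compound 4 to compound 3, 14 percentage points apart, within the scatter of two such steps. The same holds for fluoro in place of hydrogen: the same change on two cores in this assay, a number 14 percentage points higher (beyond the scatter) from compound 2 to compound 3 and no change at the digits printed (within the scatter) from compound 1 to compound 4, 14 percentage points apart, within the scatter of two such steps.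

Going by these compounds, whether a chlorine, a methoxy group or an amine on this aromatic carbon would bring the number close to that of compound 2, 85%, remains open. On these data alone, whether either exchange truly depends on the core also remains open.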